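Trimethoxyphenyl to dimethoxyphenyl on the benzylic arm

A few compounds are considered here, and "the series" means these few. Any claim that something is new, unique, unknown or untested is made for them only; others in the source may bear on it.

Of the compounds shown here, three of a shared core have been tested. Compound 1 `COc1ccc(-c2nc3cc(/C=C4\SC(=O)N(CC(=O)N5CCOCC5)C4=O)ccc3[nH]2)cc1OC` carries a morpholine amide on the ring nitrogen; in a functional assay on MDA-MB-231 cells (Homo sapiens) for inhibition, read by MTT assay, with a stated time of 48 h (a lower number here means a stronger inhibitor, a higher number a weaker inhibitor), compound 1 reaches only the limit > 50000 nM, reported as a limit and not a number. Compound 2 `COc1cc(-c2nc3cc(/C=C4\SC(=O)N(CC(=O)N5CCCCC5)C4=O)ccc3[nH]2)cc(OC)c1OC` gives 34900 nM. Compound 3 `COc1cc(CN2C(=O)S/C(=C\c3ccc4[nH]c(-c5cc(OC)c(OC)c(OC)c5)nc4c3)C2=O)cc(OC)c1OC` gives 270 nM, the lowest of the two numbers shown, and the step of a 130-fold lower number from compound 2 to compound 3 (2.11 log units; beyond the scatter) is large.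

Compound 4 `COc1ccc(-c2nc3cc(/C=C4\SC(=O)N(Cc5cc(OC)c(OC)c(OC)c5)C4=O)ccc3[nH]2)cc1OC` differs from compound 3 by hydrogen in place of methoxy on an aromatic carbon. Among the measured compounds shown here, no measured step concerns this part of the molecule: the one measured step, from compound 2 to compound 3, changes the group on the ring nitrogen, and compound 1 differs from compound 2 in two places at once, so only the values themselves are known. For compound 4 a step no larger than the scatter, or a modest rise, is therefore expected, a 1.9-fold higher number from compound 3 to compound 4 (0.27 log units; within the scatter). Compound 4 is estimated at 500 nM, between 150 nM and 2500 nM.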

Compound 4, half-maximal inhibitory concentration: 29100 nM
Beside the measured number, compound 4's estimate is 58-fold (1.76 log units) below it, and the stated range ends below it.
By their numbers in this assay, from the lowest: compound 3; then compounds 4 and 2 (each within the scatter of the next). At a limit, above all of these: compound 1.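

Among the compounds shown here, the change sits on the aryl ring of the shared core, not on the arm at the ring nitrogen, and losing this one methoxy gives a 110-fold higher number from compound 3 to compound 4 (2.03 log units; beyond the scatter) in this assay, so this ring, which no earlier measured step touched, also strongly affects the read-out. With the 3,4-dimethoxyphenyl in place, the benzylic 3,4,5-trimethoxyphenyl on the ring nitrogen gives only an at least 1.7-fold lower number from compound 1 to compound 4 (0.23 log units; that floor lies within the scatter), which can be read only as a floor. Compound 1 stands at a limit and not a number: the limit of > 50000 nM in this assay, at which 1 of the 4 values shown sits.

The compounds shown leave open whether a hydroxyl, an ethoxy or a fluorine on this aromatic carbon would keep the value of compound 3, 270 nM. They also leave open whether the methoxy groups on the benzylic arm matter as much as this one.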